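Para-Cyano Amide in a Flavonol Series

The compounds below may be only part of what the source reports. "The series", "measured", "known", "first", "only" and "open" are said of these compounds alone.

Measured so far:
compound 1 `O=C(Nc1cccc(-c2oc3cc(-c4ccc(F)cc4)ccc3c(=O)c2O)c1)c1ccc(Cl)cc1`: 4730 nM
compound 2 `Cc1cc(C)cc(C(=O)Nc2cccc(-c3oc4cc(-c5ccc(F)cc5)ccc4c(=O)c3O)c2)c1`: 20400 nM

Within the data shown here, compound 1 has the lowest number of the two in a functional assay on MCF7 cells (Homo sapiens) for antiproliferative activity, read by CCK-8 assay, with a stated time of 72 h; on this read-out higher numbers stand for weaker inhibition and lower numbers for stronger inhibition; compound 2 gives 20400 nM, and the only measured step, a 4.3-fold higher number from compound 1 to compound 2 (0.63 log units; beyond the scatter), is beyond the scatter. Compound 3 `N#Cc1ccc(C(=O)Nc2cccc(-c3oc4cc(-c5ccc(F)cc5)ccc4c(=O)c3O)c2)cc1` carries cyano in place of chloro on an aromatic carbon. Among the measured compounds shown here, no measured step replaces one para substituent on this ring with another, so the step from compound 1 to compound 2 bears only indirectly on it. Compound 3 is therefore expected to stay close to compound 1, the step of a 1.5-fold higher number from compound 1 to compound 3 (0.17 log units; within the scatter) likely lying within or only slightly beyond the scatter. Compound 3 is estimated at 7000 nM, range 2000 nM to 25000 nM.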

Compound 3, half-maximal inhibitory concentration: 2660 nM
Estimate against measurement, compound 3: 2.6-fold (0.42 log units) above; low and high end bracket the measured number.
By their numbers in this assay, from the lowest: compounds 3 and 1 (each within the scatter of the next); then compound 2.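

Chloro and cyano on this aromatic carbon, para to a large group, cannot be told apart in this assay, since the change gives a 1.8-fold lower number from compound 1 to compound 3 (0.25 log units; within the scatter). The 4-cyanophenyl amide nevertheless shows the same kind of separation from the 3,5-dimethylphenyl amide as the 4-chlorophenyl amide, with a 7.7-fold lower number from compound 2 to compound 3 (0.88 log units; beyond the scatter). Nothing measured here gives a reason for these numbers. From the compounds shown here alone, it remains open whether an amine, a methoxy group or a carboxylic acid at this position would stay level with chloro and cyano. The compounds shown also do not separate the role of the two methyl groups from that of the missing para substituent in compound 2.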